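The source may report more compounds than this note shows. Statements on the series, on what has been measured and on what is new or still open speak of the compounds shown alone.

Series notes. Compound 1 `O=C(CI)NCCCNc1ncnc2c1ncn2[C@@H]1O[C@H](COP(=O)(O)OP(=O)(O)OP(=O)(O)O)[C@@H](O)[C@H]1O` and compound 2 `O=C(CI)NCCCCCCCCNc1ncnc2c1ncn2[C@@H]1O[C@H](COP(=O)(O)OP(=O)(O)OP(=O)(O)O)[C@@H](O)[C@H]1O` differ in one place and have both been tested in an assay on isolated protein for inhibition of hexokinase-3 (Rattus norvegicus), with a stated time of 6 h, tested at 10 mM; on this read-out higher numbers stand for more inhibition at the one concentration tested (going by the name of the read-out) and lower numbers for less inhibition. Compound 1 gives 0%, while compound 2 gives 47%. Among the compounds with values here, on these two numbers compound 2 stands highest, with compound 1 its only neighbour. Compound 3 `O=C(CI)NCCC(=O)NCCCCCCNc1ncnc2c1ncn2[C@@H]1O[C@H](COP(=O)(O)OP(=O)(O)OP(=O)(O)O)[C@@H](O)[C@H]1O` has not been measured; it departs from compound 2 as follows: a group of 10 heavy atoms (5 carbon, 2 nitrogen, 2 oxygen, 1 iodine; no ring) in place of a group of 7 heavy atoms (4 carbon, 1 nitrogen, 1 oxygen, 1 iodine; no ring), on a saturated chain carbon, six bonds along the chain from a nitrogen on an aromatic ring. Within the data shown here, the one measured step that bears on this, a number 47 percentage points higher from compound 1 to compound 2 (beyond the scatter), was large and upward; compound 3 again places its group six bonds along the chain from the ring nitrogen, so only a small downward step in this assay is expected, a number 7 percentage points lower from compound 2 to compound 3 (within the scatter). Compound 3 is estimated at 40%, between 15% and 65%.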

Compound 3, a percentage reported as inhibition, at one concentration (the size of the read-out at that concentration, not a potency): 0%
Compound 3: the middle estimate sits 40 percentage points above what was measured; the measured number lies below the stated range.
By their numbers in this assay, from the lowest: compounds 1 and 3 (each within the scatter of the next); then compound 2.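

At this position, six bonds along the chain from a nitrogen on an aromatic ring, the group of 10 heavy atoms gives a number 47 percentage points lower from compound 2 to compound 3 (beyond the scatter) in this assay, with its 2 hydrogen-bond donors in place of 1. The upward step a number 47 percentage points higher from compound 1 to compound 2 (beyond the scatter) therefore does not extend to every larger group carrying the iodomethyl carbonyl end. Nothing available explains this loss.
On these data alone, whether the inner amide or the overall group size governs the result remains open. So does the reading for a longer all-carbon chain, or for an amine at that point in the chain.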